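One more methyl on the nitrogen of compound 3

The source may hold more compounds than are shown below. What is called first, only, known or untested is meant among the compounds shown, and "the series" means these compounds.

Measured in a functional assay on K562 cells (Homo sapiens), read by MTT assay, with a stated time of 72 h (on this read-out lower numbers stand for stronger inhibition and higher numbers for weaker inhibition), all three values being limits:
Compound 1 `CNc1ncnc2c1c(-c1ccccc1)cn2[C@@H]1O[C@H](CO)[C@@H](O)[C@H]1O`: > 20000 nM
Compound 2 `CNc1ncnc2c1c(-c1cc3ccccc3o1)cn2[C@@H]1O[C@H](CO)[C@@H](O)[C@H]1O`: > 20000 nM
Compound 3 `C#Cc1cn([C@@H]2O[C@H](CO)[C@@H](O)[C@H]2O)c2ncnc(NC)c12`: > 20000 nM

Compound 3 has no number, only a limit, and stands at the limit of > 20000 nM in this assay, at which 3 of the 3 values shown sit, together with the other two. Compound 4 `C#Cc1cn([C@@H]2O[C@H](CO)[C@@H](O)[C@H]2O)c2ncnc(N(C)C)c12` puts methyl in place of hydrogen on a nitrogen on an aromatic ring, turning methylamino into dimethylamino (methyl in place of hydrogen on a nitrogen on an aromatic ring). The nearest measured changes are a step that the two limits leave unreadable from compound 1 to compound 3 and a step that the two limits leave unreadable from compound 2 to compound 3 on an aromatic carbon, so neither gives a size for a change on the nitrogen. In this assay no step beyond the scatter is expected, and no direction can be named. The expected step is a number no higher from compound 3 to compound 4 (the limit leaves the size open) on this reasoning. Compound 4 is estimated at 20000 nM with an expected range from 8000 nM to 50000 nM. Compound 4 may well yield only a limit.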

Compound 4, half-maximal inhibitory concentration: 110 nM
Compound 4: the middle estimate sits 180-fold (2.26 log units) above what was measured, and the stated range ends above it.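

Up to this point, the steps between compounds 1, 2 and 3 could not be read, since all of them stayed at a limit in this assay: the limit of > 20000 nM in this assay, at which 3 of the 4 values shown sit.

Methyl in place of hydrogen on the nitrogen, turning methylamino into dimethylamino, gives an at least 180-fold lower number from compound 3 to compound 4 (2.25 log units; beyond the scatter). This nitrogen is therefore a place where a single added carbon brings the read-out from a limit to a measured number.

On these data alone, it remains open whether dimethylamino would do the same alongside the phenyl of compound 1 or the 1-benzofuran-2-yl of compound 2. As far as these compounds go, what a larger group such as diethylamino would do at this place also remains open.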